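The source may hold more compounds than are shown below. What is called first, only, known or untested is meant among the compounds shown, and "the series" means these compounds.

Measured so far:
- Compound 1, `COc1ccccc1N1CCN(CCCNc2ncccc2C(=O)NC(C)(C)C)CC1`: 1.26 nM
- Compound 2, `CCOc1ccccc1N1CCN(CCCNc2ncccc2C(=O)N(C)C)CC1`: 0.501 nM

Both compounds share the same core and were tested in a functional assay for antagonist activity at Alpha-1A adrenergic receptor (Oryctolagus cuniculus); a lower number here means tighter binding, a higher number weaker binding. Compound 2 gives 0.501 nM, the lowest number of the two. Compound 1 gives 1.26 nM, and the gap between the two lies beyond the usual scatter of this assay, so compound 2 can be taken as the tighter binder of the pair.

The next compound, compound 3, `CN(C)C(=O)c1cccnc1NCCCN1CCN(c2ccccc2C2CC2)CC1`, has not yet been measured. It is reached from compound 2 by a single exchange: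

cyclopropyl in place of ethoxy on an aromatic carbon

Within the data shown here, no pair of measured compounds shows this kind of exchange, so there is no measured step to lean on. Both measured compounds carry an oxygen-linked group at this place, and compound 3 would be the first without one. On that basis, a loss of binding strength seems the more likely outcome. The step from compound 2 to compound 3 is estimated at a 4.0-fold higher number from compound 2 to compound 3 (0.60 log units; beyond the scatter), a moderate rise in the number. Compound 3 is therefore expected to give about 2 nM, with a plausible range from 0.5 nM to 8 nM.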

Compound 3, dissociation constant: 0.631 nM
Estimate against measurement, compound 3: 3.2-fold (0.50 log units) above; low and high end bracket the measured number.
By their numbers in this assay, from the lowest: compounds 2, 3 and 1 (each within the scatter of the next, the first and the last beyond it).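

In this assay, placing cyclopropyl in place of ethoxy on an aromatic carbon, ortho to a large group, gives a 1.3-fold higher number from compound 2 to compound 3 (0.10 log units; within the scatter), so compound 2 and compound 3 cannot be told apart by this measurement. Among these compounds, compound 3 is the first compound here without an oxygen at this place: the exchange removes the one hydrogen-bond acceptor counted in ethoxy and brings in a three-membered ring of carbon only, while the count of heavy atoms stays the same. For this pair, then, an oxygen-linked group at this place is not required to keep a number of this size, although a single exchange cannot show how far that holds. Nothing measured here explains why the two groups give such similar numbers.

The compounds shown leave open how other groups would fare at this place, such as a chlorine atom, an amine, or a longer chain like propyl. They also leave open whether cyclopropyl would give a similar result when the dimethyl amide shared by compound 2 and compound 3 is replaced by the tert-butyl amide of compound 1.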